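The source may report more compounds than this note shows. Statements on the series, on what has been measured and on what is new or still open speak of the compounds shown alone.

Measured compounds:

Compound 1, `CCN(CC)CN1C(=O)/C(=N\c2nc3ccc(C)cc3s2)c2ccccc21`: in a functional assay on MDA-MB-231 cells (Homo sapiens) for cytotoxicity, read by sulforhodamine B assay, with a stated time of 48 h (on this read-out higher numbers stand for weaker inhibition of growth and lower numbers for stronger inhibition of growth), compound 1 gives 32700 nM
Compound 2, `CCN(CC)CN1C(=O)/C(=N\c2nc3ccc(C)cc3s2)c2c(Br)cccc21`: in this assay compound 2 gives 28700 nM

Compound 2 stands as the lower of the two numbers in this assay, but its nearest neighbour is compound 1, and the step of a 1.1-fold lower number from compound 1 to compound 2 (0.06 log units; within the scatter) lies within the scatter, so the two compounds cannot be told apart on this read-out.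

Compound 3, `Cc1ccc2nc(/N=C3\C(=O)N(CN(C)C)c4cccc(Br)c43)sc2c1`, has not yet been measured in this assay. It differs from compound 2 by dimethylamino in place of diethylamino on a saturated chain carbon bound to an amide-type nitrogen in a ring. Among the compounds with values here, no measured step bears on this change: the only step available, from compound 1 to compound 2, concerns bromo in place of hydrogen on an aromatic carbon and says nothing about the (diethylamino)methyl to (dimethylamino)methyl exchange. With nothing to point either way, no step beyond the scatter is expected in this assay. Compound 3 is therefore estimated at 30000 nM, within a range of 12000 nM to 75000 nM. This estimate means a step of a 1.0-fold higher number from compound 2 to compound 3 (0.02 log units; within the scatter), expected to stay within the scatter.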

Compound 3, concentration for 50% growth inhibition: 49000 nM
For compound 3 the middle estimate is 1.6-fold (0.21 log units) below the measured one, within the range that was stated.
By their numbers in this assay, from the lowest: compounds 2, 1 and 3 (each within the scatter of the next).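

In this assay, within the data shown here, dimethylamino in place of diethylamino on a saturated chain carbon bound to an amide-type nitrogen in a ring gives a 1.7-fold higher number from compound 2 to compound 3 (0.23 log units; within the scatter) and so provides the first reading at this position. The read-out therefore does not separate these two amines, even though the group goes from 5 heavy atoms to 3 with its hydrogen-bond counts unchanged. No measurement bears on why the two compounds read alike, or on what this group does in these cells.

The compounds shown cover only these two open-chain dialkylamino groups, so it remains open whether a ring amine such as piperidine or morpholine, or a carboxylic acid, would give a step beyond the scatter. Also open, from the compounds shown here alone, is whether the exchange would read the same on the core of compound 1, which carries hydrogen in place of bromo.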